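The source may hold more compounds than are shown below. What is called first, only, known or untested is meant among the compounds shown, and "the series" means these compounds.

Compound 1 `CN(C)Cc1cc(C(=O)/C=C/c2ccccc2Cl)cc(CN(C)C)c1O` gives 9550 nM in a functional assay on cells (Tumor Cell line, Homo sapiens) for cytotoxicity; on this read-out lower numbers stand for stronger inhibition and higher numbers for weaker inhibition. Compound 2 `CN(C)Cc1cc(C(=O)/C=C/c2ccc(Cl)cc2Cl)cc(CN(C)C)c1O` gives 3090 nM in this assay.

Compound 1 stands highest of the two numbers in this assay; its nearest neighbour is compound 2, reached by a 3.1-fold lower number from compound 1 to compound 2 (0.49 log units; beyond the scatter). Compound 3 `CN(C)Cc1cc(C(=O)/C=C/c2ccc(O)cc2)cc(CN(C)C)c1O` differs from compound 1 by 4-hydroxyphenyl in place of 2-chlorophenyl on a double-bonded chain carbon bound to a double-bonded chain carbon. Within the data shown here, the single measured step concerns a chloro entering an aromatic carbon and does not cover an exchange of the whole aryl group, so it bears on this change only loosely. A step of a 1.3-fold higher number from compound 1 to compound 3 (0.10 log units; within the scatter) is therefore expected, near or within the scatter. Compound 3 is estimated at 12000 nM in this assay, within 4000 nM to 36000 nM.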

Compound 3, half-maximal inhibitory concentration: 39800 nM
Compound 3: middle estimate off by 3.3-fold (0.52 log units), on the low side; measured number above the stated range.
By their numbers in this assay, from the lowest: compound 2; then compound 1; then compound 3.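

In this assay, exchanging the aryl group on this double-bonded chain carbon moves the number beyond the scatter in both comparisons: 4-hydroxyphenyl in place of 2-chlorophenyl gives a 4.2-fold higher number from compound 1 to compound 3 (0.62 log units; beyond the scatter) and 4-hydroxyphenyl in place of 2,4-dichlorophenyl gives a 13-fold higher number from compound 2 to compound 3 (1.11 log units; beyond the scatter). Compound 3 is thus the weakest of the three, and the larger step starts from the dichlorinated compound 2. Nothing available explains this rise. The compounds shown leave open whether the rise follows from losing chloro or from gaining hydroxy. Unsubstituted phenyl, 4-chlorophenyl or 4-methoxyphenyl at this place would help separate the two.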